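Swapping 3-methoxyphenyl for thiophen-2-yl on the shared core

This account rests on a few compounds, and the source may have more. Where it says the series, first, only, none or still open, it means among the compounds named here.

Compound 1 `C=C(Br)C(=O)Nc1ccc(/C=C/C(=O)c2ccc(Cl)c(Cl)c2)cc1`: 1700 nM
Compound 2 `C=C(Br)C(=O)Nc1ccc(/C=C/C(=O)c2ccc(C)cc2)cc1`: 1800 nM
Compound 3 `C=C(Br)C(=O)Nc1ccc(/C=C/C(=O)c2cccc(OC)c2)cc1`: 2300 nM

These three compounds were tested in an ADME assay on CCRF-CEM cells (Homo sapiens) for antiproliferative activity, with a stated time of 48 h; on this read-out higher numbers stand for weaker inhibition and lower numbers for stronger inhibition. Compound 3, at 2300 nM, cannot be separated from the other two. Its comparison with compound 1 is a 1.4-fold higher number from compound 1 to compound 3 (0.13 log units; within the scatter), and its comparison with compound 2 is a 1.3-fold higher number from compound 2 to compound 3 (0.11 log units; within the scatter).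

The next compound, compound 4 `C=C(Br)C(=O)Nc1ccc(/C=C/C(=O)c2cccs2)cc1`, carries thiophen-2-yl in place of 3-methoxyphenyl on a carbonyl carbon. All three measured steps bear on this change, since each replaces one aromatic group with another at that same place. The third of them is a 1.1-fold higher number from compound 1 to compound 2 (0.02 log units; within the scatter). Thus, 3,4-dichlorophenyl, 4-methylphenyl and 3-methoxyphenyl have so far given values within the scatter of one another. None of these compounds has a five-membered aromatic ring, however, so the data do not test that feature directly. On this evidence, no step beyond the scatter is expected in this assay. The expected step is a 1.2-fold lower number from compound 3 to compound 4 (0.06 log units; within the scatter). The estimated value for compound 4 is 2000 nM, with an expected range from 1000 nM to 4500 nM.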

Compound 4, half-maximal inhibitory concentration: 730 nM
The estimate for compound 4 lay 2.7-fold (0.44 log units) above the measured number; measured number outside the range, below it.
By their numbers in this assay, from the lowest: compound 4; then compounds 1, 2 and 3 (each within the scatter of the next).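

In this assay, this place on the carbonyl carbon turned out not to be indifferent to the aromatic group: thiophen-2-yl in place of 3-methoxyphenyl gives a 3.2-fold lower number from compound 3 to compound 4 (0.50 log units; beyond the scatter) and the same kind of replacement gives a 2.5-fold lower number from compound 2 to compound 4 (0.39 log units; beyond the scatter) and also a 2.3-fold lower number from compound 1 to compound 4 (0.37 log units; beyond the scatter) with each of these steps lying beyond the scatter. For the compounds shown here, the three groups with a six-membered aromatic ring of the earlier compounds had stayed within the scatter of one another, so compound 4, with its five-membered aromatic ring holding sulfur and its 5 heavy atoms, is the first compound here to stand apart, and it gives the lowest number of the four. Nothing measured here accounts for this step, so the result stands as an observation without an explanation.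

With only compound 4 carrying such a ring, the compounds shown leave open whether the step follows the five-membered ring, the sulfur atom or the smaller group as a whole. A furan-2-yl group, which has oxygen in place of sulfur, or a thiophen-3-yl group, attached through a different ring carbon, would help to separate these readings.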